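Variation at the double-bonded ring carbon of the shared core

The source may hold more compounds than are shown below. What is called first, only, known or untested is meant among the compounds shown, and "the series" means these compounds.

Measured compounds:
- compound 1, `COc1ccc2c(c1)OC(c1cc(OC)c(OC)c(OC)c1)C(C(=O)Nc1ccccc1)=C2`, 17500 nM in a functional assay for inhibition of nuclear factor NF-kappa-B complex (Homo sapiens); a lower number here means a stronger inhibitor, a higher number a weaker inhibitor
- compound 2, `COc1ccc2c(c1)OC(c1cc(OC)c(OC)c(OC)c1)C(C(=O)NC(C)C)=C2`; in this assay compound 2 gives only a limit, > 50000 nM
- compound 3, `COc1ccc2c(c1)OC(c1cc(OC)c(OC)c(OC)c1)C(/C=N/O)=C2`, 14100 nM in this assay

Compound 3 holds the lowest of the two numbers that are numbers; its nearest neighbour is compound 1, and the gap between them is a 1.2-fold lower number from compound 1 to compound 3 (0.09 log units; within the scatter), so the two cannot be ordered. The step of an at least 3.5-fold lower number from compound 2 to compound 3 (0.54 log units; beyond the scatter) goes beyond the scatter, and so does an at least 2.8-fold higher number from compound 1 to compound 2 (0.45 log units; beyond the scatter), both resting on (the limit of > 50000 nM in this assay, at which 1 of the 3 values shown sits).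

Compound 4, `CNC(=O)C1=Cc2ccc(OC)cc2OC1c1cc(OC)c(OC)c(OC)c1`, is next. The change from compound 3 is a group of 4 heavy atoms (2 carbon, 1 nitrogen, 1 oxygen; no ring) in place of a group of 3 heavy atoms (1 carbon, 1 nitrogen, 1 oxygen; no ring), on a double-bonded ring carbon. It turns the oxime into a small alkyl amide, which places compound 4 closer to compound 2 than to compound 1 among the measured amides. The relevant measured steps are therefore the step from compound 2 to compound 3 and the step from compound 1 to compound 2, both pointing to a higher number for an alkyl amide. Compound 4 is expected to give a higher number than compound 3, by about a 2.8-fold higher number from compound 3 to compound 4 (0.45 log units; beyond the scatter), with a real chance that only a limit is reported. The estimate for compound 4 in this assay is 40000 nM, within 15000 nM to 100000 nM.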

Compound 4, half-maximal inhibitory concentration: > 50000 nM
Compound 4 gave a limit, no number; the forecaster's own chance of this, stated with the estimate: 40%; middle value at least 1.2-fold (0.09 log units) away from the limit.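

Compound 4 gives > 50000 nM in this assay as a limit and not a number, so methylcarbamoyl, with methyl in place of isopropyl on the amide-type nitrogen, brings no number back, and that step, with a limit on both sides, cannot be read. The amide with methyl stands apart from the oxime by an at least 3.5-fold higher number from compound 3 to compound 4 (0.54 log units; beyond the scatter) and from the phenyl amide by an at least 2.8-fold higher number from compound 1 to compound 4 (0.45 log units; beyond the scatter) as well, so among the amides shown only the one with phenyl on the nitrogen gives a number. Both readable steps rest on the limit now shared by the two alkyl amides, compound 2 and compound 4: the limit of > 50000 nM in this assay, at which 2 of the 4 values shown sit.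

From the compounds shown here alone, what a benzyl or cyclohexyl group on the amide nitrogen would give in this assay stays open, and with it whether the number of compound 1 depends on the ring being aromatic. Also open, going by these compounds, is how a nitrile, a carboxylic acid or an aminomethyl group on the double-bonded ring carbon would compare with the oxime of compound 3, and whether any group there gives a number clearly lower than those of compound 1 and compound 3.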